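Aryl exchange on the amine-bound chain carbon: compound 4

The compounds below may be only part of what the source reports. "The series", "measured", "known", "first", "only" and "open" are said of these compounds alone.

Compound 3 `O=S(=O)(NCCCNCc1cccc2ccccc12)c1cc(C(F)(F)F)cc(C(F)(F)F)c1` in a functional assay on HPAC cells (Homo sapiens) for inhibition, read by MTT assay, with a stated time of 72 h (on this read-out higher numbers stand for weaker inhibition of growth and lower numbers for stronger inhibition of growth), gives 2400 nM. Among the three measured compounds it holds the second highest number; nearest is compound 1 `CC(C)(C)c1ccc(CNCCCNS(=O)(=O)c2cc(C(F)(F)F)cc(C(F)(F)F)c2)cc1` with 2300 nM, furthest compound 2 `O=S(=O)(NCCCNCc1ccccc1)c1cc(C(F)(F)F)cc(C(F)(F)F)c1` with 3200 nM. The step of a 1.0-fold higher number from compound 1 to compound 3 (0.02 log units; within the scatter), the step of a 1.3-fold lower number from compound 2 to compound 3 (0.12 log units; within the scatter) and the step of a 1.4-fold higher number from compound 1 to compound 2 (0.14 log units; within the scatter) all lie within the scatter, so the three aryl groups on the saturated chain carbon bound to the amine nitrogen are not separated by these numbers.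

Compound 4 `COc1cccc(CNCCCNS(=O)(=O)c2cc(C(F)(F)F)cc(C(F)(F)F)c2)c1` differs from compound 3 by 3-methoxyphenyl in place of naphthalen-1-yl on a saturated chain carbon bound to an amine nitrogen. For the measured compounds named here, the steps that bear on this change are those exchanging the same aryl group: the step of a 1.3-fold lower number from compound 2 to compound 3 (0.12 log units; within the scatter) and the step of a 1.0-fold higher number from compound 1 to compound 3 (0.02 log units; within the scatter), both within the scatter, as is the step of a 1.4-fold higher number from compound 1 to compound 2 (0.14 log units; within the scatter). No measured exchange at this position has moved this assay beyond its scatter, so no step beyond the scatter is expected here, in either direction. Compound 4 is therefore estimated at 2700 nM, with a range from 1300 nM to 5500 nM. The expected step is a 1.1-fold higher number from compound 3 to compound 4 (0.05 log units; within the scatter).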

Compound 4, concentration for 50% growth inhibition: 2400 nM
The estimate for compound 4 lay 1.1-fold (0.05 log units) above the measured number; low and high end bracket the measured number.
By their numbers in this assay, from the lowest: compounds 1, 3, 4 and 2 (each within the scatter of the next).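

In this assay the 3-methoxyphenyl group, the first here to carry a hydrogen-bond acceptor, gives no change at the digits printed from compound 3 to compound 4 (within the scatter) and the added methoxy on an aromatic carbon gives a 1.3-fold lower number from compound 2 to compound 4 (0.12 log units; within the scatter). Against the 4-(tert-butyl)phenyl group the same group gives a 1.0-fold higher number from compound 1 to compound 4 (0.02 log units; within the scatter), so four aryl groups on a saturated chain carbon bound to an amine nitrogen now stand unseparated, with no compound going against this. No data are at hand that account for this flat result.

Open, on these data alone, is whether a carboxylic acid or an amine on the aryl ring, or a cyclohexyl group in place of the aryl group, would take this number beyond the scatter. Also open, as far as these compounds go, is the effect of a longer chain in the shared core.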